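This account rests on a few compounds, and the source may have more. Where it says the series, first, only, none or still open, it means among the compounds named here.

Measured compounds in a functional assay on SF-268 cells (Homo sapiens) for inhibition, read by colorimetric assay and sulforhodamine B assay, with a stated time of 48 h; on this read-out lower numbers stand for stronger inhibition of growth and higher numbers for weaker inhibition of growth:
compound 1 `CCCCCCCCCCCC[C@@H](O)[C@H]1CC[C@H]([C@H](O)CCCCCCCCCCNC(=O)c2cccs2)O1` gives 3980 nM
compound 2 `CCCCCCCCCCCC[C@@H](O)[C@H]1CC[C@H]([C@H](O)CCCCCCCCCCNC(=O)c2ccco2)O1` gives 100000 nM
compound 3 `CCCCCCCCCCCC[C@@H](O)[C@H]1CC[C@H]([C@H](O)CCCCCCCCCCNC(=O)c2cncs2)O1` gives 100000 nM

Among the compounds with values here, compound 3 stands level with compound 2 at the digits given, and together they hold the highest numbers of the three; the only compound apart from them is compound 1, which the step of a 25-fold higher number from compound 1 to compound 3 (1.40 log units; beyond the scatter) sets well apart. Compound 4 is `CCCCCCCCCCCC[C@@H](O)[C@H]1CC[C@H]([C@H](O)CCCCCCCCCCNC(=O)c2ccnn2C)O1`. It differs from compound 3 in one place: 1-methyl-1H-pyrazol-5-yl in place of 1,3-thiazol-5-yl on a carbonyl carbon. Within the data shown here, the steps that bear on this exchange of one five-membered ring for another on the carbonyl carbon are a 25-fold higher number from compound 1 to compound 2 (1.40 log units; beyond the scatter), a 25-fold higher number from compound 1 to compound 3 (1.40 log units; beyond the scatter) and no change at the digits printed from compound 2 to compound 3 (within the scatter). The two rings that followed thiophen-2-yl both gave the same large rise, and the exchange between those two left the number unchanged. Nothing measured here points back toward the level of compound 1. For compound 4 the expected step from its parent is therefore a 1.3-fold lower number from compound 3 to compound 4 (0.10 log units; within the scatter), nothing beyond the scatter. Compound 4 is estimated at 80000 nM, within a range of 15000 nM to 100000 nM.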

Compound 4, concentration for 50% growth inhibition: 100000 nM
Compound 4: middle estimate off by 1.3-fold (0.10 log units), on the low side, and the stated range covers the measured number.
By their numbers in this assay, from the lowest: compound 1; then compounds 2, 3 and 4 (each within the scatter of the next).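

In this assay, the 1-methyl-1H-pyrazol-5-yl ring on the carbonyl carbon matches both other non-thiophene rings (no change at the digits printed from compound 3 to compound 4 (within the scatter); no change at the digits printed from compound 2 to compound 4 (within the scatter)). Set against the thiophen-2-yl ring, it gives a large step (a 25-fold higher number from compound 1 to compound 4 (1.40 log units; beyond the scatter)), so three different replacements for that ring now share one level, including one that carries a methyl group and has more heavy atoms than 1,3-thiazol-5-yl. Of the four rings, only the thiophen-2-yl ring of compound 1 stands apart, and nothing measured here explains why.

The compounds shown leave open whether the lower number of compound 1 is kept by a thiophen-3-yl group or a phenyl ring on the carbonyl carbon. They also leave open what a chlorine atom or an amine on the thiophen-2-yl ring would do.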